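Dimethylamino to acetamido on the shared core

The source may report more compounds than this note shows. Statements on the series, on what has been measured and on what is new or still open speak of the compounds shown alone.

Measured in a functional assay (aorta) with Rattus norvegicus as the target; a higher number here means that more compound is needed for the effect, a lower number that less compound is needed:
- compound 1 `COc1ccc(-c2nc(/N=C(\N)NC3CCCCC3)sc2-c2ccc(OC)cc2)cc1`: > 100 uM
- compound 2 `COc1ccc(-c2nc(CN(C)C)sc2-c2ccc(OC)cc2)cc1`: 8.4 uM

The value of compound 1 is a limit of the assay. For the measured compounds named here, compound 2, at 8.4 uM, holds the only actual number so far. Compound 3 `COc1ccc(-c2nc(CNC(C)=O)sc2-c2ccc(OC)cc2)cc1` differs from it by acetamido in place of dimethylamino on a saturated chain carbon bound to an aromatic carbon. Going by the values given here, the one measured step, an at least 11-fold lower number from compound 1 to compound 2 (1.07 log units; beyond the scatter), is large, rests on the limit of > 100 uM in this assay, at which 1 of the 2 values shown sits, and involves a different group, so it bears only loosely on this change. It does show that a group exchange can move the number far. A moderate rise of a 1.8-fold higher number from compound 2 to compound 3 (0.25 log units; within the scatter) is expected in this assay, with wide uncertainty. For compound 3 the estimate is 15 uM, with an expected range from 3 uM to 80 uM.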

Compound 3, concentration for half-maximal effect: 8.1 uM
For compound 3 the middle estimate is 1.9-fold (0.27 log units) above the measured one; the measured number falls inside the stated range.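

In this assay, acetamido in place of dimethylamino on a saturated chain carbon bound to an aromatic carbon leaves the two compounds indistinguishable: a 1.0-fold lower number from compound 2 to compound 3 (0.02 log units; within the scatter). The low number of compound 2 therefore does not depend on dimethylamino alone, since an uncharged acetamido with a hydrogen-bond donor also retains it, and the second group also stands well apart from the group of compound 1: an at least 12-fold lower number from compound 1 to compound 3 (1.09 log units; beyond the scatter). That wider step rests on a limit for compound 1: the limit of > 100 uM in this assay, at which 1 of the 3 values shown sits.

Open, going by these compounds, is whether a primary amine, a carboxylic acid or a longer chain at this place would keep the number in this range. The compounds shown also leave open whether any group here can lower it further.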